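The compounds below may be only part of what the source reports. "The series", "measured", "known", "first", "only" and "open" are said of these compounds alone.

Measured compounds:
compound 1 `N#Cc1c(Cl)nc(SCC(=O)Nn2c(COc3ccc(Cl)cc3Cl)nc3ccccc3c2=O)nc1-c1ccccc1` — 66.7%
compound 2 `N#Cc1c(Cl)nc(SCC(=O)Nn2c(COc3ccc(Cl)cc3Cl)nc3ccccc3c2=O)nc1-c1ccc(Cl)cc1` — 68.4%
compound 3 `N#Cc1c(Cl)nc(SCC(=O)Nn2c(COc3ccc(Cl)cc3Cl)nc3ccccc3c2=O)nc1-c1ccc(O)cc1` — 73.7%

All three numbers come from a functional assay on the whole organism (strain albino) for inhibition, with Rattus norvegicus as the target, read by paw edema, with stated times of 1 h and 2 h, at a dose of 100 mg/kg by the oral route; a lower number here means less inhibition, a higher number more inhibition at the dose given (going by the name of the read-out). Compound 1 stands lowest of the three, but none of the gaps leaves the scatter: the nearest number is that of compound 2, a number 1.7 percentage points higher from compound 1 to compound 2 (within the scatter), and the furthest is that of compound 3, a number 7 percentage points higher from compound 1 to compound 3 (within the scatter). Between the two substituted analogues the gap is also small, a number 5.3 percentage points higher from compound 2 to compound 3 (within the scatter). Every measured step concerns only the phenyl group on the shared core; the three values are read as one level with no ordering among them.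

Compound 4 `N#Cc1c(Nc2ccccc2)nc(SCC(=O)Nn2c(COc3ccc(Cl)cc3Cl)nc3ccccc3c2=O)nc1-c1ccccc1` is not yet measured. Relative to compound 1 the change is anilino in place of chloro on an aromatic carbon. Within the data shown here, no measured step touches this position of the core, so nothing among the three measured compounds bears directly on the change; what the measured steps do show is that the series so far has stayed at one level whatever was altered. Among the measured compounds shown here, with no step in hand to argue for movement, the expected step is none beyond the scatter, a number 0.3 percentage points higher from compound 1 to compound 4 (within the scatter). For compound 4 in this assay the estimate is 67%, with a range from 54% to 80%, the width of which reflects the absence of any measured step at this position.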

Compound 4, a percentage reported as inhibition, in the whole organism at one dose (the size of the read-out at that dose, not a potency): 78.1%
Compound 4: middle estimate off by 11.1 percentage points, on the low side; measured number inside the range.
By their numbers in this assay, from the lowest: compounds 1, 2, 3 and 4 (each within the scatter of the next, the first and the last beyond it).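

In this assay, among these compounds, the chloro of compound 1, on the aromatic carbon next to the ring nitrogen and ortho to a cyano group, gives way to anilino with a number 11.4 percentage points higher from compound 1 to compound 4 (beyond the scatter) and this is the only step so far that lies beyond the scatter. The earlier compounds shown here differed only on the phenyl group and gave no reading at this position. It now accepts a much larger group, with an added six-membered aromatic ring and a hydrogen-bond donor where a single chlorine stood, and inhibition at the dose given does not fall.

As far as these compounds go, a plain amino group, a morpholino group or a benzylamino group at this position would be needed to separate the contribution of the aromatic ring from that of the amine hydrogen, and the effect of a methoxy or a nitro group on the anilino ring also remains open. No measurement among the data at hand bears on the origin of this step.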